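The source may report more compounds than this note shows. Statements on the series, on what has been measured and on what is new or still open speak of the compounds shown alone.

Measured in an ADME assay on MT4 cells (Homo sapiens) for cytotoxicity, read by MTT assay; a lower number here means that less compound is tolerated, a higher number that more compound is tolerated:
Compound 1 `O=C(CSc1nc(Cc2c(F)cccc2F)cc(=O)[nH]1)c1ccccc1`: > 67000 nM, a limit of the assay
Compound 2 `Cc1c(Cc2c(F)cccc2F)nc(SCC(=O)c2ccccc2)[nH]c1=O`: 65000 nM

Among the compounds with values here, compound 2 gives the only actual number so far in this assay. Compound 3 `CCc1c(Cc2c(F)cccc2F)nc(SCC(=O)c2ccccc2)[nH]c1=O` is reached from compound 2 by methyl in place of hydrogen on a saturated chain carbon bound to an aromatic carbon, methyl to ethyl. Within the data shown here, one measured step bears on this: an at least 1.0-fold lower number from compound 1 to compound 2 (0.01 log units; that floor lies within the scatter), also methyl in place of hydrogen, though on an aromatic carbon. On that evidence, a 1.3-fold lower number from compound 2 to compound 3 (0.11 log units; within the scatter) is expected to stay within the scatter, with no clear direction. Compound 3 is estimated at 50000 nM, with an expected range from 22000 nM to 90000 nM.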

Compound 3, half-maximal cytotoxic concentration: 56000 nM
Estimate against measurement, compound 3: 1.1-fold (0.05 log units) below; the measured number falls inside the stated range.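

In this assay the change from methyl to ethyl gives a 1.2-fold lower number from compound 2 to compound 3 (0.06 log units; within the scatter) between two actual numbers, so compound 2 and compound 3 cannot be told apart, and this saturated chain carbon bound to an aromatic carbon takes the added methyl without a clear difference. The step spanning both additions gives an at least 1.1-fold lower number from compound 1 to compound 3 (0.07 log units; that floor lies within the scatter) as its reading, but this is only a floor because compound 1 stands at a limit of the assay: the limit of > 67000 nM in this assay, at which 1 of the 3 values shown sits.

On these data alone, whether a longer chain such as propyl would also stay within the scatter of compound 2 remains open. So does the outcome with an amine or a carboxylic acid in the same place.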